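From Compound 2 to Compound 3: Limits Only So Far

This account rests on a few compounds, and the source may have more. Where it says the series, first, only, none or still open, it means among the compounds named here.

In a functional assay on HEK293 cells (Homo sapiens) for cytotoxicity (a higher number here means that more compound is tolerated, a lower number that less compound is tolerated), compound 1 (`COc1ccc([C@H]2CC(=O)N(c3cccc(O)c3)C2)cc1OC1CCCC1`) gives > 10000 nM as a limit of the assay and not a number. Compound 2 (`COc1ccc([C@H]2CC(=O)N(c3ccncc3)C2)cc1OC1CCCC1`) stands in this assay at > 10000 nM and this too is only a limit. Among the compounds with values here, the one measured step is a step that the two limits leave unreadable from compound 1 to compound 2 and it offers no size to carry forward. All the data show so far is the limit of > 10000 nM in this assay, at which 2 of the 2 values shown sit, with no measured number behind it. The change to compound 3 (`COc1ccc([C@H]2CC(=O)N(c3cccc([S+](C)[O-])c3)C2)cc1OC1CCCC1`) is a group of 9 heavy atoms (7 carbon, 1 oxygen, 1 sulfur; one six-membered aromatic ring of carbon only) in place of a group of 6 heavy atoms (5 carbon, 1 nitrogen; one six-membered aromatic ring with 1 hetero atom), on an amide-type nitrogen in a ring and this compound has yet to be measured. Within the data shown here, the only guide is the limit of compound 2 at > 10000 nM and nothing more. No step beyond the scatter is expected in this assay and the estimated change is a step that the limit leaves unreadable from compound 2 to compound 3 with no direction favoured. Compound 3 is estimated at 15000 nM with an expected range from 7000 nM to 40000 nM and will probably be reported again as a limit.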

Compound 3, half-maximal cytotoxic concentration: > 10000 nM
Compound 3: no number, only a limit; the forecaster's own chance of this, stated with the estimate: 85%; the middle value is on the limit's open side.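

In this assay, within the data shown here, compound 3 gives > 10000 nM, again a limit of the assay and not a number, and no step from compound 1 or compound 2 to compound 3 can be read. The compounds shown leave open whether any group on the amide-type nitrogen in a ring would give a measured number in this assay.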